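The source may hold more compounds than are shown below. What is called first, only, known or untested is meant among the compounds shown, and "the series" means these compounds.

The measured compounds:

Compound 1, `COc1ccc(NC(=O)c2cn(-c3ccccc3)nc2-c2ccccc2)cc1`, gives 1350 nM in a functional assay on HCT-116 cells (Homo sapiens) for cytotoxicity, read by MTT assay, with a stated time of 48 h; on this read-out lower numbers stand for stronger inhibition and higher numbers for weaker inhibition.
Compound 2, `CCOc1ccc(NC(=O)c2cn(-c3ccccc3)nc2-c2ccccc2)cc1`, gives 620 nM in this assay.
Compound 3, `COc1ccc(NC(=O)c2cn(-c3ccccc3)nc2-c2ccc([N+](=O)[O-])cc2)cc1`, gives 1020 nM in this assay.

Compound 4, `CCOc1ccc(NC(=O)c2cn(-c3ccccc3)nc2-c2ccc([N+](=O)[O-])cc2)cc1`, has not yet been measured in this assay. It stands to compound 3 as compound 2 stands to compound 1. The change from compound 3 to compound 4 is methyl in place of hydrogen on a saturated chain carbon bound to an oxygen on an aromatic ring. The same change, made once before, is methyl in place of hydrogen on a saturated chain carbon bound to an oxygen on an aromatic ring, and it produced a 2.2-fold lower number from compound 1 to compound 2 (0.34 log units; beyond the scatter). The two cores differ by nitro in place of hydrogen on an aromatic carbon, and that difference by itself gave a 1.3-fold lower number from compound 1 to compound 3 (0.12 log units; within the scatter), so compound 1 and compound 3 lie close together. In both pairs the change sits at the same place, a saturated chain carbon bound to an oxygen on an aromatic ring, so the two changes are the same change, not merely the same kind. Among the four compounds this change occurs only twice, so a single measured pair is all that is available to guide the expectation, and the cores themselves stand close together.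

The expected step from compound 3 to compound 4 in this assay is a 2.1-fold lower number from compound 3 to compound 4 (0.33 log units; beyond the scatter). That expectation rests on compound 1 and compound 2, whose step was a 2.2-fold lower number from compound 1 to compound 2 (0.34 log units; beyond the scatter). Compound 4 is therefore estimated at 480 nM in this assay, with a range from 240 nM to 1000 nM.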

Compound 4, half-maximal inhibitory concentration: 390 nM
The estimate for compound 4 lay 1.2-fold (0.09 log units) above the measured number; low and high end bracket the measured number.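

Replacing methoxy with ethoxy on the nitro-bearing core gave a 2.6-fold lower number from compound 3 to compound 4 (0.42 log units; beyond the scatter) in this assay, and this step agrees with the one on the core of compound 1: the same change on two cores in this assay, a 2.2-fold lower number (0.34 log units; beyond the scatter) from compound 1 to compound 2 and a 2.6-fold lower number (0.42 log units; beyond the scatter) from compound 3 to compound 4, 1.2-fold (0.08 log units) apart, within the scatter of two such steps. The nitro change, read on the ethoxy compounds, gave a 1.6-fold lower number from compound 2 to compound 4 (0.20 log units; within the scatter), and on both the methoxy and the ethoxy compounds it stays within the scatter: the same change on two cores in this assay, a 1.3-fold lower number (0.12 log units; within the scatter) from compound 1 to compound 3 and a 1.6-fold lower number (0.20 log units; within the scatter) from compound 2 to compound 4, 1.2-fold (0.08 log units) apart, within the scatter of two such steps. Together these pairs show that the methyl added to the methoxy chain carried over between these two cores with much the same size, but they rest on only two cores in a single assay, so they do not show that the step would hold on other cores, nor do they explain why it arises.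

The compounds shown leave open whether a longer chain, such as propoxy or butoxy, would continue the step or end it, and whether the step would persist on a core with an amine or a carboxylic acid in place of the nitro group. They also leave open whether the same steps would appear in cell lines other than the one tested here.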